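A few compounds are considered here, and "the series" means these few. Any claim that something is new, unique, unknown or untested is made for them only; others in the source may bear on it.

Compound 1 `CC(=O)N1N=C(c2cccc3ccccc23)CC1c1ccccc1` and compound 2 `CC(=O)N1N=C(c2cccc3ccccc23)CC1c1ccccc1[N+](=O)[O-]` share one core, while compound 3 `O=CCN1N=C(c2ccc3ccccc3c2)CC1c1ccccc1` and compound 4 `O=CCN1N=C(c2ccc3ccccc3c2)CC1c1cccc([N+](=O)[O-])c1` share another; the difference between the two cores is not broken down here. In a functional assay on OVCAR cells (Homo sapiens) for cytotoxicity, read by sulforhodamine B assay, with a stated time of 48 h (a lower number here means a stronger inhibitor, a higher number a weaker inhibitor), compound 1 gives 7820 nM and compound 2 gives 4320 nM. The change between them is nitro in place of hydrogen on an aromatic carbon and it made a step of a 1.8-fold lower number from compound 1 to compound 2 (0.26 log units; within the scatter). Compound 3 gives 21500 nM in this assay, the highest of the three numbers, and its gap to compound 1 and to compound 2 lies beyond the scatter. Compound 4 differs from compound 3 by nitro in place of hydrogen on an aromatic carbon, the same kind of change as before, though here the nitro sits meta to a large group, whereas in compound 2 it sits ortho to a large group. The expectation rests on the earlier step, because a 1.8-fold lower number from compound 1 to compound 2 (0.26 log units; within the scatter) stayed within the scatter. For compound 4 a similarly small step is expected, a 1.8-fold lower number from compound 3 to compound 4 (0.25 log units; within the scatter). Compound 4 is estimated at 12000 nM in this assay, with a likely range from 5000 nM to 35000 nM.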

Compound 4, half-maximal inhibitory concentration: 3390 nM
Beside the measured number, compound 4's estimate is 3.5-fold (0.55 log units) above it; the whole stated range lies above it.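

In this assay, the nitro group gives a 6.3-fold lower number from compound 3 to compound 4 (0.80 log units; beyond the scatter), and this step does not match the one seen on the other core: the same change on two cores in this assay, a 1.8-fold lower number (0.26 log units; within the scatter) from compound 1 to compound 2 and a 6.3-fold lower number (0.80 log units; beyond the scatter) from compound 3 to compound 4, 3.5-fold (0.54 log units) apart, beyond the scatter of two such steps. The size of the step therefore did not carry over from the core of compound 1 to the core of compound 3, so a step measured on one core is a poor guide to the same change on the other. This does not show why the two steps differ, since the pairs differ both in their core and in where the nitro group sits, meta to a large group in compound 4 but elsewhere on the ring in compound 2, and one pair per core cannot separate these two differences.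

Going by these compounds, it remains open whether the nitro group in the place it holds in compound 4 would give a larger step on the core of compound 1. On these data alone, it is also open whether an amine or a carboxylic acid in that same place on compound 3 would give a step of similar size.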